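The source may report more compounds than this note shows. Statements on the series, on what has been measured and on what is new or still open speak of the compounds shown alone.

Of the compounds shown here, three sharing one core have been measured in a functional assay on SW620/5-FU cells (Homo sapiens) for cytotoxicity, read by MTT assay, with a stated time of 48 h, in the presence of a further agent that is not named here; on this read-out lower numbers stand for an effect already at smaller amounts and higher numbers for an effect only at larger amounts of compound. Compound 1 `Cn1ncc2c(-c3ccccc3)cc(NNC(=O)Nc3cc(Cl)nc(Cl)c3)nc21` gives 76900 nM, the highest of the three numbers. Compound 2 `Cn1ncc2c(-c3ccc(F)cc3)cc(NNC(=O)Nc3cc(Cl)nc(OCCF)c3)nc21` gives 29300 nM, and compound 3 `Cn1nc(C(F)(F)F)c2c(-c3ccccc3)cc(NNC(=O)Nc3cc(Cl)nc(Cl)c3)nc21` gives 13100 nM. Among the compounds with values here, the only single-point step among them, a 5.9-fold lower number from compound 1 to compound 3 (0.77 log units; beyond the scatter), concerns a position other than the one now changed. Compound 4 `CCCc1cc(NNC(=O)Nc2cc(Cl)nc(Cl)c2)nc2c1cnn2C` differs from compound 1 in one place: propyl in place of phenyl on an aromatic carbon. Within the data shown here, no measured step bears on an exchange of this kind, so the data give no direction for it, and the step of a 1.1-fold lower number from compound 1 to compound 4 (0.04 log units; within the scatter) is therefore expected to stay within the scatter, with wide uncertainty. The estimate for compound 4 in this assay is 70000 nM, between 20000 nM and 200000 nM.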

Compound 4, half-maximal effective concentration: 38700 nM
Beside the measured number, compound 4's estimate is 1.8-fold (0.26 log units) above it; the range from low to high includes it.
By their numbers in this assay, from the lowest: compound 3; then compounds 2, 4 and 1 (each within the scatter of the next, the first and the last beyond it).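

Exchanging phenyl for propyl on this aromatic carbon, opposite the ring nitrogen, gives a 2.0-fold lower number from compound 1 to compound 4 (0.30 log units; within the scatter) in this assay. Within the data shown here, the six-membered aromatic ring can thus leave this position for a chain with no ring without a step beyond the scatter, which the earlier compounds, none of which changes this position alone, could not show. Nothing available explains this result.

As far as these compounds go, whether a shorter chain such as methyl, a longer chain such as hexyl, or an amine on this carbon would give a similar number stays open. So does whether propyl would behave alike on the trifluoromethyl-bearing core of compound 3.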